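The source may report more compounds than this note shows. Statements on the series, on what has been measured and on what is new or still open speak of the compounds shown alone.

Working notes on the series. Compound 1 `CCN(CC)c1nc(C)c2[nH]c(SCC(=O)NCCCN)nc2n1` carries the shared core with a thio-linked amide chain. In an ADME assay on CEM174 cells (Homo sapiens) for cytotoxicity (on this read-out lower numbers stand for higher toxicity in this test and higher numbers for lower toxicity in this test), compound 1 gives > 100 uM, which is a limit of the assay and not a number. Compound 2 `CCN(CC)CC[n+]1c(SCC(=O)NCCCN)[nH]c2c(C)nc(N(CC)CC)nc21` bears the same chain on a charged form of the core. In this assay compound 2 gives > 100 uM, also a limit. Compound 3 `CCN(CC)c1nc(C)c2[nH]c(SCC(=O)NCCCN)[n+](CCCN(C)C)c2n1` differs from compound 2 by the step that the two limits leave unreadable from compound 2 to compound 3, and the two limits leave its size unreadable. In this assay compound 3 gives > 100 uM, again a limit. Compound 3 thus stands at the limit of > 100 uM in this assay, at which 3 of the 3 values shown sit, and no value in the series separates itself from any other.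

Compound 4 `CCN(CC)c1nc(C)c2[nH]c(SCC(=O)NCCNC(=N)N)[n+](CCCN(C)C)c2n1` differs from compound 3 by a group of 4 heavy atoms (1 carbon, 3 nitrogen; no ring) in place of a group of 2 heavy atoms (1 carbon, 1 nitrogen; no ring), on a saturated chain carbon, two bonds along the chain from an amide-type nitrogen. For the measured compounds named here, no measured step touches this part of the chain; the only step with a direction, from compound 2 to compound 3, is unreadable, and every value so far sits at the limit of > 100 uM in this assay, at which 3 of the 3 values shown sit. In this assay no step beyond the scatter is expected from compound 3 to compound 4, estimated as a step that the limit leaves unreadable from compound 3 to compound 4. Compound 4 is therefore expected to give 150 uM in this assay, in a range from 50 uM to 500 uM, most likely reported once more only as a limit.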

Compound 4, half-maximal toxic concentration: > 100 uM
Compound 4: no number, only a limit; the forecaster's own chance of this, stated with the estimate: 80%; the middle value is on the limit's open side.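

Compound 4 gives > 100 uM in this assay as a limit of the assay and not a number. No step can be read from compound 3 to compound 4 because both values are limits: the limit of > 100 uM in this assay, at which 4 of the 4 values shown sit. The compounds shown leave open at what concentration any of them turns toxic, and whether the two chain ends differ at all.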